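The source may hold more compounds than are shown below. What is called first, only, known or untested is meant among the compounds shown, and "the series" means these compounds.

Measured so far:
- compound 1, `Cc1ccccc1Cc1cnc(N)nc1N`: in an assay for inhibition of Dihydrofolate reductase (Gallus gallus) (a higher number here means a weaker inhibitor, a lower number a stronger inhibitor), compound 1 gives 29500 nM
- compound 2, `CCOc1ccccc1Cc1cnc(N)nc1N`: in this assay compound 2 gives 24500 nM
- compound 3, `CS(=O)(=O)Oc1ccccc1Cc1cnc(N)nc1N`: in this assay compound 3 gives 22900 nM

All three compounds share the same core and differ only in the group on one aromatic carbon of the phenyl ring. Compound 3 sits alongside the other two in this assay: the gap from compound 2 to compound 3 is a 1.1-fold lower number from compound 2 to compound 3 (0.03 log units; within the scatter) and the gap from compound 1 to compound 3 is a 1.3-fold lower number from compound 1 to compound 3 (0.11 log units; within the scatter), so the three numbers cannot be told apart with confidence.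

Compound 4, `Nc1ncc(Cc2ccccc2Cl)c(N)n1`, is the next step. The change is chloro in place of (methylsulfonyl)oxy on an aromatic carbon. Within the data shown here, the steps that bear on this are those in which the same position was changed before: from compound 1 to compound 2 the number moved by a 1.2-fold lower number from compound 1 to compound 2 (0.08 log units; within the scatter), and from compound 1 to compound 3 by a 1.3-fold lower number from compound 1 to compound 3 (0.11 log units; within the scatter). Three quite different groups at this position left this assay essentially unchanged. Chloro is a small group like methyl in compound 1, so no step beyond the scatter is expected here either.

The estimated step from compound 3 to compound 4 is a 1.1-fold higher number from compound 3 to compound 4 (0.06 log units; within the scatter). Compound 4 is therefore expected to give about 26000 nM in this assay, with a likely range from 9000 nM to 70000 nM.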

Compound 4, inhibition constant: 17400 nM
Estimate against measurement, compound 4: 1.5-fold (0.17 log units) above; low and high end bracket the measured number.
By their numbers in this assay, from the lowest: compounds 4, 3, 2 and 1 (each within the scatter of the next).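

Chloro brings a halogen to this position for the first time, and with it the smallest group seen here: one heavy atom in place of the five of (methylsulfonyl)oxy, yet in this assay the result is a 1.3-fold lower number from compound 3 to compound 4 (0.12 log units; within the scatter). The comparisons with the other two groups read the same way, with chloro in place of ethoxy giving a 1.4-fold lower number from compound 2 to compound 4 (0.15 log units; within the scatter) and chloro in place of methyl giving a 1.7-fold lower number from compound 1 to compound 4 (0.23 log units; within the scatter), so all four groups on this aromatic carbon remain indistinguishable, even though the last of these steps is the largest seen so far at this position. No measurement on hand explains why this position tolerates such different groups in this assay.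

From the compounds shown here alone, it remains open whether an amine, a carboxylic acid or a longer chain such as butoxy at this position would produce a step beyond the scatter in this assay. Also open is whether a second group added to the phenyl ring of these compounds would leave the number just as unchanged, or whether this insensitivity holds only for a single group on this carbon.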